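This account rests on a few compounds, and the source may have more. Where it says the series, first, only, none or still open, it means among the compounds named here.

Working notes on the series built on the shared core of compound 1 `COc1cc(-c2nn(-c3cccc(NC(=O)Nc4cc(C(F)(F)F)cc(C(F)(F)F)c4)c3)cc2-c2ccncc2)ccc1Cl`. In a functional assay on A549 cells (Homo sapiens) for inhibition, read by sulforhodamine B assay, with a stated time of 48 h (a higher number here means a weaker inhibitor of growth, a lower number a stronger inhibitor of growth), compound 1 gives 2130 nM. Compound 2 `COc1cc(-c2nn(-c3cccc(NC(=O)Nc4cccc(C(F)(F)F)c4)c3)cc2-c2ccncc2)ccc1Cl` carries one trifluoromethyl fewer on the urea-linked aryl ring. In this assay compound 2 reaches only the limit of the assay, > 50000 nM, and its standing is known solely as that bound (the limit of > 50000 nM in this assay, at which 1 of the 2 values shown sits). Among the compounds with values here, the only measured step, an at least 23-fold higher number from compound 1 to compound 2 (1.37 log units; beyond the scatter), was large and moved towards weaker growth inhibition.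

Compound 3 `COc1cc(-c2nn(-c3cccc(NC(=O)c4ccccc4)c3)cc2-c2ccncc2)ccc1Cl` takes the change further: phenyl in place of (3-(trifluoromethyl)phenyl)amino on a carbonyl carbon, so the urea becomes an amide and no trifluoromethyl remains. Within the data shown here, the step of an at least 23-fold higher number from compound 1 to compound 2 (1.37 log units; beyond the scatter) removed less than this and still cost heavily, and no measured step runs the other way. Compound 3 is therefore expected to stay at the limit, with an estimated step that the limit leaves unreadable from compound 2 to compound 3. The estimate for compound 3 in this assay is 60000 nM, within a range of 20000 nM to 200000 nM.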

Compound 3, concentration for total growth inhibition: > 100000 nM
Compound 3: no number, only a limit (the forecaster's own chance of this, stated with the estimate: 80%); at least 1.6-fold (0.22 log units) between middle value and limit.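

In this assay compound 3 gives > 100000 nM, a limit and not a number. Within the data shown here, compound 2 gives > 50000 nM, also a limit, and no step between compound 2 and compound 3 can be read. The compounds shown leave open how far apart these two truly lie in growth inhibition.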